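The source may report more compounds than this note shows. Statements on the series, on what has been measured and on what is new or still open speak of the compounds shown alone.

For the measured compounds named here, compound 1, `O=c1c2ccccc2ccn1[C@@H]1O[C@H](COP(=O)(O)OP(=O)(O)OP(=O)(O)O)[C@@H](O)[C@H]1O`, is the point of departure; in a functional assay for agonist activity at P2Y purinoceptor 2 (Homo sapiens), read by FLIPR (a higher number here means that more compound is needed for the effect, a lower number that less compound is needed), compound 1 gives 31 nM, the lowest of the three numbers measured so far. Compound 2, `Cc1cn([C@@H]2O[C@H](COP(=O)(O)OP(=O)(O)OP(=O)(O)O)[C@@H](O)[C@H]2O)c(=O)c2ccccc12`, gives 17500 nM, and compound 3, `Cc1cccc2ccn([C@@H]3O[C@H](COP(=O)(O)OP(=O)(O)OP(=O)(O)O)[C@@H](O)[C@H]3O)c(=O)c12`, gives 85 nM. Both measured steps add a methyl to the shared core: a 560-fold higher number from compound 1 to compound 2 (2.75 log units; beyond the scatter) and a 2.7-fold higher number from compound 1 to compound 3 (0.44 log units; beyond the scatter). Compound 4, `N#Cc1ccc2c(=O)n([C@@H]3O[C@H](COP(=O)(O)OP(=O)(O)OP(=O)(O)O)[C@@H](O)[C@H]3O)ccc2c1`, differs from compound 1 by cyano in place of hydrogen on an aromatic carbon. Going by the values given here, neither measured step touches this site, so they show only that adding a group to the core has, in both cases, raised the number in this assay, once by a large and once by a modest amount. A modest rise is therefore expected, a 2.3-fold higher number from compound 1 to compound 4 (0.35 log units; beyond the scatter). Compound 4 is estimated at 70 nM, with a range from 15 nM to 350 nM.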

Compound 4, half-maximal effective concentration: 88 nM
Beside the measured number, compound 4's estimate is 1.3-fold (0.10 log units) below it, within the range that was stated.
By their numbers in this assay, from the lowest: compound 1; then compounds 3 and 4 (each within the scatter of the next); then compound 2.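

Adding cyano at this site, on the six-membered aromatic ring of carbon only, gives a 2.8-fold higher number from compound 1 to compound 4 (0.45 log units; beyond the scatter) in this assay. This first look at the site shows that the change costs only a modest amount, far less than a 560-fold higher number from compound 1 to compound 2 (2.75 log units; beyond the scatter) seen with methyl at another site. No measurement here explains the rise. On these data alone, whether the modest step belongs to cyano itself or would hold for other groups at this site stays open. An amine or a carboxylic acid here could give a quite different number.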